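Lengthening a Chain That Already Sits at the Limit

The source may report more compounds than this note shows. Statements on the series, on what has been measured and on what is new or still open speak of the compounds shown alone.

Compound 1 `[O-]/[N+](=C\c1cn(-c2ccc(Cl)cc2)nn1)c1ccccc1`: 8900 nM
Compound 2 `CCCCCCCCCCn1cc(/C=[N+](\[O-])c2ccccc2)nn1`: > 100000 nM
Compound 3 `CCCCCCCCn1cc(/C=[N+](\[O-])Cc2ccccc2)nn1`: > 100000 nM

Of the compounds shown here, three have been read in a functional assay on MDA-MB-231 cells (Homo sapiens) for inhibition, read by MTT assay, with a stated time of 24 h; on this read-out lower numbers stand for stronger inhibition and higher numbers for weaker inhibition. Compound 1 gives 8900 nM in this assay. Compound 2 is reported only as a limit of the assay, > 100000 nM. Compound 3 is likewise reported only as a limit, > 100000 nM, so no number is known for it. Compound 3 therefore stands at the ceiling of what this assay records, and it shares that place with one other compound, since (the limit of > 100000 nM in this assay, at which 2 of the 3 values shown sit). For the measured compounds named here, no pair among the three differs in a single place, so no measured step is available to guide expectations.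

Compound 4 `CCCCCCCCCCn1cc(/C=[N+](\[O-])Cc2ccccc2)nn1` is the next compound to be read. It differs from compound 3 by ethyl in place of hydrogen on a saturated chain carbon, eight bonds along the chain from an aromatic nitrogen. Going by the values given here, with compound 3 already at the limit, and with no measured step to suggest otherwise, the chain lengthening is expected to produce no change beyond the scatter, that is a step that the limit leaves unreadable from compound 3 to compound 4. Compound 4 is accordingly estimated at 150000 nM in this assay, within a range from 50000 nM to 500000 nM, and most likely it too will be reported only as a limit.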

Compound 4, half-maximal inhibitory concentration: > 100000 nM
Compound 4: only a limit was reported; the forecaster's own chance of this, stated with the estimate: 85%; the middle value is on the limit's open side.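

Compound 4 is reported in this assay only as a limit, so neither its step from compound 3 nor its step from compound 2 can be read: the limit of > 100000 nM in this assay, at which 3 of the 4 values shown sit.

The compounds shown leave open how far compounds 2, 3 and 4 each lie past that limit, and whether the longer chain of compound 4 changes anything there.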